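Methoxyphenyl Piperazine Replaces Methylpiperazine on the Shared Core

The source may report more compounds than this note shows. Statements on the series, on what has been measured and on what is new or still open speak of the compounds shown alone.

Compound 2 `C/C1=C\CC[C@@]2(C)O[C@@H]2[C@H]2OC(=O)[C@@H](CN3CCN(C)CC3)[C@@H]2C[C@H]1O` gives 25000 nM in a functional assay on B16-F10 cells (Mus musculus) for inhibition, read by colorimetric assay and MTT assay, with a stated time of 72 h (a higher number here means a weaker inhibitor, a lower number a stronger inhibitor), the highest of the two numbers recorded, while compound 1 `C/C1=C\CC[C@@]2(C)O[C@@H]2[C@H]2OC(=O)[C@@H](CN3CCCCC3)[C@@H]2C[C@H]1O` stands nearest with 4000 nM. Among the measured compounds shown here, the single measured step, a 6.3-fold higher number from compound 1 to compound 2 (0.80 log units; beyond the scatter), alters the amine ring itself rather than a substituent on it. Compound 3 `COc1ccc(N2CCN(C[C@@H]3C(=O)O[C@H]4[C@H]3C[C@@H](O)/C(C)=C/CC[C@@]3(C)O[C@H]43)CC2)cc1` differs from compound 2 in one place: 4-methoxyphenyl in place of methyl on an amine nitrogen in a ring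

For the measured compounds named here, no measured pair varies a group on that ring nitrogen, so nothing here bears directly on this change. The expected step is therefore of uncertain direction, a 2.1-fold lower number from compound 2 to compound 3 (0.32 log units; beyond the scatter). Compound 3 is estimated at 12000 nM, within 3000 nM to 50000 nM.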

Compound 3, half-maximal inhibitory concentration: 14000 nM
Beside the measured number, compound 3's estimate is 1.2-fold (0.07 log units) below it; the range from low to high includes it.
By their numbers in this assay, from the lowest: compound 1; then compounds 3 and 2 (each within the scatter of the next).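

In this assay, the ring nitrogen carries 4-methoxyphenyl in place of methyl with a 1.8-fold lower number from compound 2 to compound 3 (0.25 log units; within the scatter), so a group of eight heavy atoms with an aromatic ring on this amine nitrogen leaves the reading within the scatter. The earlier step changed the amine ring itself, whereas this one shows that a much larger substituent on that nitrogen can be accommodated without a clear loss or gain. No measurement on hand offers an explanation for this result.

The compounds shown leave open whether a plain phenyl, a benzyl or an acetyl group on that nitrogen would read the same. They also leave open what the methoxy group on the aromatic ring contributes, which a hydroxyl or a fluorine there could test.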